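The source may report more compounds than this note shows. Statements on the series, on what has been measured and on what is new or still open speak of the compounds shown alone.

In an ADME assay on L6 cells (Rattus norvegicus) for cytotoxicity, with a stated time of 72 h (on this read-out higher numbers stand for weaker inhibition and lower numbers for stronger inhibition), compound 3 `CC(=O)OC1CC2(N3CCCC3)CC(c3ccccc3)C1C(c1ccccc1)C2` has no number to start from: its entry reads "not determined" (no result reported) and so it holds no place on the scale. Two relatives sharing its core do have numbers. In this assay compound 1 `O=C(/C=C/c1ccccc1)OC1CC2(N3CCCC3)CC(c3ccccc3)C1C(c1ccccc1)C2` gives 3500 nM and compound 2 `O=C(CN1CCCCC1)OC1CC2(N3CCCC3)CC(c3ccccc3)C1C(c1ccccc1)C2` gives 14200 nM there. The change from compound 3 to compound 4 `O=C(CN1CCCC1)OC1CC2(N3CCCC3)CC(c3ccccc3)C1C(c1ccccc1)C2` is pyrrolidin-1-yl in place of hydrogen on a saturated chain carbon bound to a carbonyl carbon and it can also be read as methyl to (pyrrolidin-1-yl)methyl. For the measured compounds named here, only one measured step bears on this: a 4.1-fold higher number from compound 1 to compound 2 (0.61 log units; beyond the scatter) with (piperidin-1-yl)methyl in place of 2-phenylethenyl on a carbonyl carbon. Compound 2 carries (piperidin-1-yl)methyl where compound 4 carries (pyrrolidin-1-yl)methyl, which makes compound 2 its closest measured relative. With no number for compound 3, no size or direction can be expected for the step itself, so the expectation rests on compound 2 at 14200 nM alone. Compound 4 is expected at about 12000 nM with an estimated range from 5000 nM to 30000 nM as the likely span.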

Compound 4, half-maximal inhibitory concentration: 42900 nM
The estimate for compound 4 lay 3.6-fold (0.55 log units) below the measured number; measured number above the stated range.
By their numbers in this assay, from the lowest: compound 1; then compound 2; then compound 4.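

In this assay, for the compounds shown here, the identity of the amine ring on the saturated chain carbon bound to a carbonyl carbon matters, which the earlier compounds could not show: a 3.0-fold higher number from compound 2 to compound 4 (0.48 log units; beyond the scatter), with pyrrolidin-1-yl in place of piperidin-1-yl, and the shift lies beyond the usual scatter. Measured against the 2-phenylethenyl group, (pyrrolidin-1-yl)methyl gives a larger change, a 12-fold higher number from compound 1 to compound 4 (1.09 log units; beyond the scatter), than the one already seen for (piperidin-1-yl)methyl. Nothing available explains why exchanging one amine ring for the other moves the number in this way.

As far as these compounds go, with no number for compound 3, the step from compound 3 to compound 4 cannot be read, so the effect of adding any amine to the acetyl methyl remains unknown. Also open, from the compounds shown here alone, is how a morpholine ring, an open-chain dimethylamino group or a longer chain would fall relative to these compounds.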